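This account rests on a few compounds, and the source may have more. Where it says the series, first, only, none or still open, it means among the compounds named here.

Measured compounds:
Compound 1, `Cc1ccc(/C=C2\CN(C)CC3C2=NN(c2ccccc2)C3c2ccc(C)cc2)cc1`, in a functional assay on cells (Panel leukemia (Carcinoma cell lines), Homo sapiens) for inhibition (a lower number here means a stronger inhibitor of growth, a higher number a weaker inhibitor of growth), compound 1 gives 37400 nM.
Compound 2, `COc1ccc(/C=C2\CN(C)CC3=C2N=C(S)NC3c2ccc(OC)cc2)cc1`, in this assay compound 2 gives 2000 nM.
Compound 3, `CN1C/C(=C\c2cccs2)C2=NN(C)C(c3cccs3)C2C1`, in this assay compound 3 gives 31800 nM.

Among these three numbers, compound 3 stands second highest in this assay. Its nearest neighbour is compound 1, whose number lies within the scatter of that of compound 3, so the two cannot be told apart. Compound 2 stands furthest away, with a number well beyond the scatter below that of compound 3.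

Compound 4, `CN1C/C(=C\c2cccs2)C2=NN(c3ccccc3)C(c3cccs3)C2C1`, has not yet been measured. It differs from compound 3 in one place: phenyl in place of methyl on an amine nitrogen in a ring. Among the measured compounds shown here, no pair of measured compounds shares exactly this change, so no directly comparable step exists. What the data show is that compound 1, which carries the phenyl on that ring nitrogen, and compound 3, which carries the methyl there, give numbers within the scatter of each other, although their other groups differ as well. On that basis compound 4 is expected to stay close to compound 3, with a step of a 1.1-fold lower number from compound 3 to compound 4 (0.03 log units; within the scatter) that is not expected to go beyond the scatter in either direction. Compound 4 is therefore estimated at 30000 nM in this assay, within a range from 8000 nM to 100000 nM.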

Compound 4, concentration for 50% growth inhibition: 2200 nM
Compound 4: the middle estimate sits 14-fold (1.13 log units) above what was measured; the whole stated range lies above it.
By their numbers in this assay, from the lowest: compounds 2 and 4 (each within the scatter of the next); then compounds 3 and 1 (each within the scatter of the next).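

In this assay, phenyl in place of methyl on this amine nitrogen in a ring gives a 14-fold lower number from compound 3 to compound 4 (1.16 log units; beyond the scatter), so what this position carries matters a great deal for inhibition of growth. This is the only step shown that isolates a change in one place, and it ties the stronger inhibition to the entering phenyl, with its six-membered aromatic ring of carbon only, while the thiophen-2-yl group and the rest of the compound stay the same. Nothing measured here bears on why the step is this large.

It remains open whether the aromatic ring itself is needed, as the compounds shown offer no ethyl, benzyl or 4-methoxyphenyl group on this nitrogen. They also leave open whether the same change would give a step of this size with a group other than thiophen-2-yl on the neighbouring ring atom.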